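The compounds below may be only part of what the source reports. "The series", "measured", "known", "first", "only" and "open" are said of these compounds alone.

Measured so far:
- compound 1, `CN(c1ccc2cc(NC(=O)CCc3ccc(C(F)(F)F)cc3)ccc2n1)C1CCCCC1`: 18 nM
- compound 2, `CC1CCN(c2ccc3cc(NC(=O)CCc4ccc(C(F)(F)F)cc4)ccc3n2)C1`: 2 nM
- compound 3, `Nc1ccc2cc(NC(=O)CCc3ccc(C(F)(F)F)cc3)ccc2n1`: 240 nM

All three share a core and differ only in the group sitting on one aromatic carbon of that core. In an assay on isolated protein for displacement of a labelled ligand from melanin-concentrating hormone receptor 1 (Homo sapiens) (on this read-out lower numbers stand for stronger inhibition and higher numbers for weaker inhibition), compound 3, which carries a plain amino group there, gives the highest of the three numbers, so it is the weakest binder of the set. The step of a 13-fold higher number from compound 1 to compound 3 (1.12 log units; beyond the scatter) and the step of a 120-fold higher number from compound 2 to compound 3 (2.08 log units; beyond the scatter) both show that replacing a larger nitrogen substituent with the bare amino group raises the number well beyond the scatter.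

Compound 4, `CCN(CC)c1ccc2cc(NC(=O)CCc3ccc(C(F)(F)F)cc3)ccc2n1`, has not yet been measured. It differs from compound 3 in one place: diethylamino in place of amino on an aromatic carbon. The two measured steps bear directly on this change, since both run from a substituted nitrogen to the amino group and both are large. Going the other way, from amino to diethylamino, a lower number is therefore expected in this assay, and the size is expected to lie in the range spanned by those two steps, most likely closer to the smaller one. For compound 4 the estimate is 20 nM, with a range from 5 nM to 80 nM, which corresponds to an expected step of a 12-fold lower number from compound 3 to compound 4 (1.08 log units; beyond the scatter).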

Compound 4, half-maximal inhibitory concentration: 88 nM
Compound 4: the middle estimate sits 4.4-fold (0.64 log units) below what was measured, and the stated range ends below it.
By their numbers in this assay, from the lowest: compound 2; then compound 1; then compound 4; then compound 3.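

Replacing amino with diethylamino in this assay gives a 2.7-fold lower number from compound 3 to compound 4 (0.44 log units; beyond the scatter), so putting two ethyl groups on this nitrogen helps, but only modestly, a much smaller gain than the other two substituted nitrogens show over the amino group. Diethylamino also falls behind both of those groups, with a 4.9-fold higher number from compound 1 to compound 4 (0.69 log units; beyond the scatter) and, much larger, a 44-fold higher number from compound 2 to compound 4 (1.64 log units; beyond the scatter), so at this position on the ring, next to the ring nitrogen, it matters which carbon groups the nitrogen carries, not only that the hydrogens of amino are gone. Nothing available explains why these three groups differ so widely, so the ranking stands here as an observation without a cause.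

The compounds shown cannot separate the effect of the closed ring in compound 2 from that of its methyl group, and a plain pyrrolidin-1-yl or a piperidin-1-yl group on the same carbon would bear on that question. They also leave open how a smaller dimethylamino group would compare, and whether a group with no nitrogen at this place, such as methoxy, would bind at all.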